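A Thioether Arm Traded From Triazole to Aminothiazole

This account rests on a few compounds, and the source may have more. Where it says the series, first, only, none or still open, it means among the compounds named here.

Of the compounds shown here, three sharing one core have been measured in an assay on CHO cells for displacement of a labelled ligand from adenosine receptor A1 (Homo sapiens), read by scintillation counting, with a stated time of 90 min; on this read-out higher numbers stand for weaker inhibition and lower numbers for stronger inhibition. Compound 1 `CCOc1ccc(-c2c(C#N)c(N)nc(SCc3ccn[nH]3)c2C#N)cc1` gives 21 nM. Compound 2 `N#Cc1c(N)nc(SCc2ncn[nH]2)c(C#N)c1-c1ccc(OCC2CC2)cc1` gives 338 nM, and compound 3 `C=C(C)COc1ccc(-c2c(C#N)c(N)nc(SCC(N)=O)c2C#N)cc1` gives 872 nM. Among these three numbers compound 2 stands second highest: its nearest neighbour is compound 3, whose number is higher by a margin beyond the scatter, while compound 1 sits far below it, again beyond the scatter. No pair of these compounds differs in a single place, so the three values are simply read side by side.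

Compound 4 `N#Cc1c(N)nc(SCc2csc(N)n2)c(C#N)c1-c1ccc(OCC2CC2)cc1` has not yet been measured in this assay. It is derived from compound 2 by one change: 2-amino-1,3-thiazol-4-yl in place of 1H-1,2,4-triazol-5-yl on a saturated chain carbon bound to a sulfur. The group that leaves and the group that enters are both five-membered aromatic rings carrying one hydrogen-bond donor, and the thioether link and the rest of the molecule are untouched. For the measured compounds named here, with no measured step of this kind to lean on, the account expects the move from compound 2 to compound 4 to be modest, a 1.4-fold lower number from compound 2 to compound 4 (0.13 log units; within the scatter), within or just beyond the scatter and leaning toward a lower number. On that basis compound 4 is estimated at 250 nM in this assay, with a plausible range from 60 nM to 1000 nM.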

Compound 4, inhibition constant: 140 nM
Estimate against measurement, compound 4: 1.8-fold (0.25 log units) above; the measured number falls inside the stated range.
By their numbers in this assay, from the lowest: compound 1; then compound 4; then compound 2; then compound 3.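

On the saturated chain carbon bound to a sulfur, the first comparison in one place among these compounds gives a 2.4-fold lower number from compound 2 to compound 4 (0.38 log units; beyond the scatter) in this assay, showing that the number at this position depends on which five-membered aromatic ring the chain carbon carries. The exchange takes the ring from 3 hetero atoms to 2, from 5 heavy atoms to 6 and from 2 hydrogen-bond acceptors to 3, while 1 hydrogen-bond donor stands on each side, so the step comes without any change in the donor count. Nothing measured here ties the step to any one of these differences.

The compounds shown leave open whether the amino group of 2-amino-1,3-thiazol-4-yl matters to the step, a question that the plain 1,3-thiazol-4-yl or 2-methyl-1,3-thiazol-4-yl on the same chain carbon would address. Going by these compounds, compound 1 and compound 3 each differ from compound 4 in more than one place, so it also remains open whether the same exchange would give a similar step with the ether arm of either compound.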